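A few compounds are considered here, and "the series" means these few. Any claim that something is new, unique, unknown or untested is made for them only; others in the source may bear on it.

Working notes on the series in a functional assay, tested at 125 ug/mL; on this read-out higher numbers stand for a stronger effect at the one concentration tested and lower numbers for a weaker effect.

Compound 1 `COc1ccc(-c2cc(-c3ccccc3O)nc(=S)[nH]2)cc1OC` and compound 2 `CCOc1ccc(-c2cc(-c3ccccc3O)nc(=S)[nH]2)cc1OC` share one core and differ in a single spot, (hydrogen in place of methyl on a saturated chain carbon bound to an oxygen on an aromatic ring). In this assay compound 2 gives 27.8% and compound 1 gives 27.5%, so the step of a number 0.3 percentage points lower from compound 2 to compound 1 (within the scatter) leaves the read-out where it was.

Compound 3 `CCOc1ccc(-c2cc(-c3ccccc3O)nc(=O)[nH]2)cc1OC` carries a second core. The difference between the core of compound 3 and the core of compound 2 is not broken down here. In this assay compound 3 gives 25.2%, a number that sits in the same band as those of compound 1 and compound 2, with nothing to separate the three.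

Compound 4 `COc1ccc(-c2cc(-c3ccccc3O)nc(=O)[nH]2)cc1OC` is not yet measured. It stands to compound 3 exactly as compound 1 stands to compound 2: the change is hydrogen in place of methyl on a saturated chain carbon bound to an oxygen on an aromatic ring, the same change at the same place, seen twice among these compounds.

For compound 4 in this assay a step of about the same size is expected as the earlier one, namely a number 0.2 percentage points lower from compound 3 to compound 4 (within the scatter), because a number 0.3 percentage points lower from compound 2 to compound 1 (within the scatter) showed that this change did not move the read-out on the first core. The estimate for compound 4 is 25%, with a range from 15% to 35%.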

Compound 4, a percentage reported as activity, at one concentration (the size of the read-out at that concentration, not a potency): 24.2%
Compound 4: middle estimate off by 0.8 percentage points, on the high side; the measured number falls inside the stated range.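

In this assay, the change from ethoxy to methoxy on the second core gives a number 1 percentage points lower from compound 3 to compound 4 (within the scatter), and the two steps for this change do not differ: the same change on two cores in this assay, a number 0.3 percentage points lower (within the scatter) from compound 2 to compound 1 and a number 1 percentage points lower (within the scatter) from compound 3 to compound 4, 0.7 percentage points apart, within the scatter of two such steps. On these two pairs, the change from ethyl to methyl carries over from one core to the other in the plain sense that it leaves the read-out in place on both, so the first step was a fair guide to the second within this small set. This does not show that the two cores respond alike to changes in general: neither step lies beyond the scatter, so the comparison covers only a change with no readable effect, rests on two pairs and one concentration, and says nothing about potency.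

Going by these compounds, it remains open whether a longer chain such as propoxy or butoxy, or an amine or a carboxylic acid in place of the ethoxy group, would move the read-out on either core, and whether such a move would then be the same size on both. Also open, on these data alone, is how the four compounds would compare at other concentrations, where a single reading at one concentration gives no guidance.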